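Moving the fluorine around the anilino ring

The source may report more compounds than this note shows. Statements on the series, on what has been measured and on what is new or still open speak of the compounds shown alone.

Compound 1, `CCCOc1ccc(C(=O)Nc2cccc(Nc3ccccc3)n2)cc1`, was examined in an in vitro assay on HEK-tsA201 cells for antagonist activity at Neuronal acetylcholine receptor; alpha3/beta4 (Homo sapiens), read by fluorescence and calcium flux; a lower number here means a stronger inhibitor, a higher number a weaker inhibitor. In this assay compound 1 gives only a limit, > 100000 nM. Compound 2, `CCCOc1ccc(C(=O)Nc2cccc(Nc3ccccc3F)n2)cc1`, carries a fluoro in place of hydrogen on an aromatic carbon. In this assay compound 2 likewise gives only a limit, > 100000 nM. The step that the two limits leave unreadable from compound 1 to compound 2 cannot be sized because the limit of > 100000 nM in this assay, at which 2 of the 2 values shown sit, holds both of its ends, so compound 2 stands at a limit and nowhere else on the numbers at hand.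

Compound 3, `CCCOc1ccc(C(=O)Nc2cccc(Nc3cccc(F)c3)n2)cc1`, has not yet been measured. It differs from compound 2 by 3-fluorophenyl in place of 2-fluorophenyl on a nitrogen on an aromatic ring; cut one bond further out, the same difference reads (2-fluorophenyl)amino to (3-fluorophenyl)amino. Within the data shown here, the only measured step, a step that the two limits leave unreadable from compound 1 to compound 2, touches the same ring but has no readable size, so no measured step sets a direction or a size for the change from compound 2 to compound 3. Since compound 2 sits at a limit, compound 3 is expected to remain there, and the step that the limit leaves unreadable from compound 2 to compound 3 is the estimated outcome. Compound 3 is thus estimated at 200000 nM, between 30000 nM and 1000000 nM, with a report of only a limit the most likely result.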

Compound 3, half-maximal inhibitory concentration: > 100000 nM
Compound 3 gave a limit, no number; the forecaster's own chance of this, stated with the estimate: 85%; the middle value lies beyond the limit too.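

In this assay compound 3 also stands at a limit, so neither its step from compound 1 nor its step from compound 2 can be read, and the three compounds cannot be told apart: the limit of > 100000 nM in this assay, at which 3 of the 3 values shown sit. The compounds shown leave open how strongly any of the three inhibits, and whether phenyl, 2-fluorophenyl and 3-fluorophenyl differ at all.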